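From Hydroxyphenyl to Dichlorophenyl at the Assay Limit

This account rests on a few compounds, and the source may have more. Where it says the series, first, only, none or still open, it means among the compounds named here.

Compound 1 `COc1ccccc1/C=C1\CCC/C(=C\c2ccc(OC)c(OC)c2)C1=O`: > 20000 nM (a limit)
Compound 2 `COc1ccc(/C=C2\CCC/C(=C\c3ccc(O)cc3)C2=O)cc1OC`: > 20000 nM (a limit)

In a functional assay on A549 cells (Homo sapiens) for cytotoxicity, read by MTT assay, with a stated time of 72 h (a lower number here means a stronger inhibitor, a higher number a weaker inhibitor), compound 2 has no exact number and stands only at the limit of > 20000 nM in this reading. The move to compound 3 `COc1ccc(/C=C2\CCC/C(=C\c3ccc(Cl)cc3Cl)C2=O)cc1OC` makes one change, 2,4-dichlorophenyl in place of 4-hydroxyphenyl on a double-bonded chain carbon bound to a double-bonded ring carbon. One measured step swaps a group at this same place, a step that the two limits leave unreadable from compound 1 to compound 2 and so it offers no size to carry over. Compound 1 and compound 2 share a single reading, the limit of > 20000 nM in this assay, at which 2 of the 2 values shown sit, and neither has a number of its own. With no readable step to lean on, no clear gain in strength is expected in this assay and another reading at the limit is quite possible. The expected move is a number no higher from compound 2 to compound 3 (the limit leaves the size open) and this estimate is a loose one. For compound 3 the estimated value is 20000 nM with an expected range from 8000 nM to 40000 nM in this assay.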

Compound 3, half-maximal inhibitory concentration: > 20000 nM
Compound 3: no number, only a limit; the forecaster's own chance of this, stated with the estimate: 65%; the middle value sits exactly at the limit.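

Compound 3 gives only a limit, not a number, in this assay, so no step among compound 1, compound 2 and compound 3 can be read, and none has a size: the limit of > 20000 nM in this assay, at which 3 of the 3 values shown sit.

The compounds shown leave open whether changing the group on the double-bonded chain carbon alters strength at all, and by how much.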